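A few compounds are considered here, and "the series" means these few. Any claim that something is new, unique, unknown or untested is made for them only; others in the source may bear on it.

Of the compounds shown here, three have been measured in a functional assay on HCT-116 cells (Homo sapiens) for inhibition, read by MTT assay, with a stated time of 2 days, tested at 10 uM; a lower number here means less inhibition, a higher number more inhibition at the concentration tested (going by the name of the read-out). Compound 2 `COc1ccc(OC)c(-c2cn(-c3ccc(O)c(C(=O)OCCCc4ccccc4)c3)nn2)c1` gives 13%, the second highest of the three numbers. Compound 1 `COc1ccc(-c2cn(-c3ccc(O)c(C(=O)Nc4cccc(C(F)(F)F)c4)c3)nn2)cc1` gives 9%, which lies within the usual scatter of compound 2, while compound 3 `O=C(Nc1cccc(C(F)(F)F)c1)c1cc(-n2cc(-c3cccc(O)c3)nn2)ccc1O` gives 25%, a gap beyond the scatter. For the measured compounds named here, the one measured step, a number 16 percentage points higher from compound 1 to compound 3 (beyond the scatter), concerns a different aromatic group from the one altered here, so it does not directly bear on the present change. Compound 4 `COc1ccccc1-c1cn(-c2ccc(O)c(C(=O)OCCCc3ccccc3)c2)nn1` differs from compound 2 by hydrogen in place of methoxy on an aromatic carbon. Going by the values given here, with no measured step on this change, no shift beyond the scatter is expected. Compound 4 is therefore estimated at 13%, in a range from 3% to 25%, which means an expected step of no change at the digits printed from compound 2 to compound 4 (within the scatter).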

Compound 4, a percentage reported as inhibition, at one concentration (the size of the read-out at that concentration, not a potency): 7%
The estimate for compound 4 lay 6 percentage points above the measured number; measured number inside the range.
By their numbers in this assay, from the lowest: compounds 4, 1 and 2 (each within the scatter of the next); then compound 3.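

For the compounds shown here, the change from 2,5-dimethoxyphenyl to 2-methoxyphenyl in this assay gives a number 6 percentage points lower from compound 2 to compound 4 (within the scatter) and so offers the first direct reading of hydrogen in place of methoxy at this position. On this reading, the methoxy group is not shown to matter for the number at the concentration tested. No measured evidence here explains the result.

As far as these compounds go, whether another group at this position, such as an amine or a carboxylic acid, would move the number beyond the scatter remains open. So does whether the same change would read alike on a compound with the amide found in compound 1 and compound 3.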